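Ortho Chloro for Methyl on the Benzyl Ring

This account rests on a few compounds, and the source may have more. Where it says the series, first, only, none or still open, it means among the compounds named here.

Compound 1 `Cc1ccc(Cn2cc(COc3ccc4c(=O)ccoc4c3)nn2)cc1` gives 68500 nM in a functional assay on QGY7701 cells (Homo sapiens) for cytotoxicity, read by MTT assay, with a stated time of 48 h; on this read-out higher numbers stand for weaker inhibition and lower numbers for stronger inhibition. Among the compounds with values here, compound 2 `O=c1ccoc2cc(OCc3cn(Cc4cccc(Br)c4)nn3)ccc12` gives 17600 nM in this assay, and the step of a 3.9-fold lower number from compound 1 to compound 2 (0.59 log units; beyond the scatter) is the only clearly resolved change among the measured pairs. Compound 3 `Cc1ccccc1Cn1cc(COc2ccc3c(=O)ccoc3c2)nn1` is reported in this assay only as a limit, > 100000 nM, not as a number. That limit is the limit of > 100000 nM in this assay, at which 1 of the 3 values shown sits. The steps of an at least 1.4-fold higher number from compound 1 to compound 3 (0.16 log units; that floor lies within the scatter) and an at least 5.6-fold higher number from compound 2 to compound 3 (0.75 log units; beyond the scatter) place compound 3 at the weak end of the shown numbers, its true value open.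

Compound 4 `O=c1ccoc2cc(OCc3cn(Cc4ccccc4Cl)nn3)ccc12` differs from compound 3 by chloro in place of methyl on an aromatic carbon. Within the data shown here, no measured step swaps methyl for chloro at this place; the nearest guide is a 3.9-fold lower number from compound 1 to compound 2 (0.59 log units; beyond the scatter), where 3-bromophenyl replaced 4-methylphenyl and the number fell modestly. A halogen for a methyl on the benzyl ring is therefore expected to lower the number modestly in this assay, though the limit at compound 3 blurs the starting point. Compound 4 is expected to give 60000 nM, between 20000 nM and 150000 nM, which is an estimated step of an at least 1.6-fold lower number from compound 3 to compound 4 (0.22 log units; that floor lies within the scatter).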

Compound 4, half-maximal inhibitory concentration: 19700 nM
For compound 4 the middle estimate is 3.0-fold (0.48 log units) above the measured one; the measured number lies below the stated range.
By their numbers in this assay, from the lowest: compounds 2 and 4 (each within the scatter of the next); then compound 1. At a limit, above all of these: compound 3.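

Chloro in place of methyl on an aromatic carbon, ortho to a large group, gives an at least 5.0-fold lower number from compound 3 to compound 4 (0.70 log units; beyond the scatter), a change resolved at one place in the series, though only as a floor, since compound 3 is a limit and not a number: the limit of > 100000 nM in this assay, at which 1 of the 4 values shown sits. A 2-substituted ring can therefore sit at the low end of the series, and the 2-chlorophenyl and 3-bromophenyl groups cannot be told apart: a 1.1-fold higher number from compound 2 to compound 4 (0.05 log units; within the scatter). Both halogen-bearing compounds lie on the low side of the methyl compounds, with a 3.5-fold lower number from compound 1 to compound 4 (0.54 log units; beyond the scatter) adding the comparison with the 4-methylphenyl group.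

As far as these compounds go, the true size of the methyl-to-chloro step stays open, as does whether chloro reads the same elsewhere on the ring. From the compounds shown here alone, how a fluoro, a methoxy or an amine would read at this place also stays open.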